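Furan-3-yl for Bromo: Expected Change in Microsomal Clearance

The source may hold more compounds than are shown below. What is called first, only, known or untested is meant among the compounds shown, and "the series" means these compounds.

Measured so far:
compound 1, `Nc1ccc(S(=O)(=O)N2CCN(c3ncc(C(O)(C(F)(F)F)C(F)(F)F)cc3Br)CC2)cn1`: < 14 mL.min-1.g-1
compound 2, `Cn1cc(-c2cc(C(O)(C(F)(F)F)C(F)(F)F)cnc2N2CCN(S(=O)(=O)c3ccc(N)nc3)CC2)cn1`: 19 mL.min-1.g-1

In an ADME assay (liver) for metabolic stability, with Liver microsome (Homo sapiens) as the target, using microsomes and NADPH, with a stated time of 30 min, tested at 1 uM (a higher number here means faster removal of the compound, a lower number slower removal), compound 1 gives < 14 mL.min-1.g-1, which is a limit of the assay rather than a number. In this assay compound 2 gives 19 mL.min-1.g-1. The step between them is an at least 1.3-fold higher number from compound 1 to compound 2 (0.13 log units; that floor lies within the scatter), its floor resting on (the limit of < 14 mL.min-1.g-1 in this assay, at which 1 of the 2 values shown sits), so the true size of that step is not known.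

Compound 3, `Nc1ccc(S(=O)(=O)N2CCN(c3ncc(C(O)(C(F)(F)F)C(F)(F)F)cc3-c3ccoc3)CC2)cn1`, has not yet been measured. It differs from compound 1 in one place: furan-3-yl in place of bromo on an aromatic carbon. The only measured step that bears on this change is the one from compound 1 to compound 2, where bromo also gave way to a five-membered aromatic ring and the number rose by at least the amount shown, though the floor of that rise lies within the scatter. A change of the same kind is therefore expected here, most likely a modest rise in this assay.

Compound 3 is expected to give about 25 mL.min-1.g-1, with a range from 10 mL.min-1.g-1 to 60 mL.min-1.g-1. The expected step is an at least 1.7-fold higher number from compound 1 to compound 3 (0.25 log units; that floor lies within the scatter).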

Compound 3, intrinsic clearance in microsomes: < 14 mL.min-1.g-1
Compound 3 ended at the assay's limit (the forecaster's own chance of this, stated with the estimate: 20%); middle value at least 1.7-fold (0.25 log units) away from the limit.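

Compound 3, with furan-3-yl on this aromatic carbon, gives < 14 mL.min-1.g-1 in this assay, which is a limit of the assay and not a number, so a five-membered aromatic ring at this position does not by itself carry the number off that limit. Compound 2 is the one compound shown here that stands clear of the limit, and replacing its 1-methyl-1H-pyrazol-4-yl with furan-3-yl gives an at least 1.3-fold lower number from compound 2 to compound 3 (0.13 log units; that floor lies within the scatter), so any difference between these two rings is not established and the true size of the step is not known. The step from bromo to furan-3-yl cannot be read, because both of its ends rest on the same limit: the limit of < 14 mL.min-1.g-1 in this assay, at which 2 of the 3 values shown sit.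

On these data alone, the true numbers of compound 1 and compound 3 remain open, so bromo and furan-3-yl cannot be placed in order in this assay. Also open, as far as these compounds go, is how the number would respond to an amine, a carboxylic acid or a longer alkyl chain on this aromatic carbon, ortho to a large group.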